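The source may hold more compounds than are shown below. What is called first, only, known or untested is meant among the compounds shown, and "the series" means these compounds.

Measured so far in a functional assay on HT-29 cells (Homo sapiens) for inhibition, read by sulforhodamine B assay, with a stated time of 48 h; a higher number here means a weaker inhibitor of growth, a lower number a stronger inhibitor of growth:

compound 1, `CCOC(=O)C1=C(C)NC(=O)NC1c1ccc(SC)cc1` — 10.2 ug/mL
compound 2, `CCOC(=O)C1=C(C)NC(=O)NC1C1CCCCC1` — > 250 ug/mL, which is a limit of the assay and not a number

Among the measured compounds shown here, compound 1 carries the only number obtained so far in this assay. Compound 2 sits at the limit of > 250 ug/mL in this assay, at which 1 of the 2 values shown sits. For the measured compounds named here, no step between compound 1 and compound 2 can therefore be stated; the pair shows only that compound 1 returned a number where compound 2 did not.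

Compound 3, `CCCc1ccc(C2NC(=O)NC(C)=C2C(=O)OCC)cc1`, is the next compound to be run in this assay. Relative to compound 1 the change is propyl in place of methylsulfanyl on an aromatic carbon; the shared core and the ethyl ester, methyl group and aromatic ring of compound 1 are kept. Going by the values given here, no measured step of this kind exists, so the size of the change is unknown. The step from compound 1 to compound 3 is expected to be small, a 1.3-fold higher number from compound 1 to compound 3 (0.11 log units; within the scatter), with no direction beyond the scatter. Compound 3 is accordingly estimated at 13 ug/mL, with a range from 4 ug/mL to 45 ug/mL.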

Compound 3, concentration for 50% growth inhibition: 17.5 ug/mL
The estimate for compound 3 lay 1.3-fold (0.13 log units) below the measured number; the measured number falls inside the stated range.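

In this assay, the series now has its first readable step at this position, on an aromatic carbon para to a large group: propyl in place of methylsulfanyl gives a 1.7-fold higher number from compound 1 to compound 3 (0.23 log units; within the scatter). This pair therefore sets methylsulfanyl and propyl level within the scatter, even though the exchange removes the sulfur and the hydrogen-bond acceptor counted for methylsulfanyl, so neither is required in this pair for a measurable number in this assay. No measured information explains the size of this step.

Among the compounds shown here, whether an amine, a carboxylic acid or a chain longer than propyl at this position would move the number beyond the scatter remains open, as one step describes only this single exchange. Compound 2 remains at a limit of the assay and not a number, so steps involving compound 2 cannot be read.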